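This account rests on a few compounds, and the source may have more. Where it says the series, first, only, none or still open, it means among the compounds named here.

Three compounds with a shared saturated bicyclic amine core, each carrying a differently substituted thiophene ring, have been tested in an ADME assay on MDCK cells (Canis lupus familiaris) for cytotoxicity, read by microscopy, with a stated time of 48 h; on this read-out higher numbers stand for lower toxicity in this test and lower numbers for higher toxicity in this test. Compound 1 `CCCCc1csc(CN[C@@H]2C[C@H]3C[C@@H]([C@H]2C)C3(C)C)c1` gives 12500 nM, compound 2 `CCCc1csc(CN[C@@H]2C[C@H]3C[C@@H]([C@H]2C)C3(C)C)c1` gives 12500 nM, and compound 3 `C[C@H]1[C@H](NCc2cc(Br)cs2)C[C@H]2C[C@@H]1C2(C)C` gives 6250 nM. Compound 3 has the lowest of the three numbers, but its steps to the other two, a 2.0-fold lower number from compound 1 to compound 3 (0.30 log units; within the scatter) and a 2.0-fold lower number from compound 2 to compound 3 (0.30 log units; within the scatter), both stay within the scatter, so the three compounds cannot be ranked against each other on these data. Shortening the chain, no change at the digits printed from compound 1 to compound 2 (within the scatter), also left the number unchanged.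

The next compound, compound 4 `C=Cc1csc(CN[C@@H]2C[C@H]3C[C@@H]([C@H]2C)C3(C)C)c1`, differs from compound 3 in one place: vinyl in place of bromo on an aromatic carbon. The two steps that bear on this change are those in which bromo replaced a saturated carbon chain at the same place on the ring, from compound 1 to compound 3 and from compound 2 to compound 3. Both moved the number only within the scatter. Since vinyl, like propyl and butyl, is a short carbon chain on that ring carbon, the expected step of a 1.4-fold higher number from compound 3 to compound 4 (0.15 log units; within the scatter) from compound 3 to compound 4 is therefore small, if anything back toward the numbers of compounds 1 and 2. For compound 4 in this assay, the estimate is 8800 nM, with a range from 3100 nM to 25000 nM.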

Compound 4, minimum cytotoxic concentration: 6250 nM
Beside the measured number, compound 4's estimate is 1.4-fold (0.15 log units) above it, within the range that was stated.
By their numbers in this assay, from the lowest: compounds 3, 4, 1 and 2 (each within the scatter of the next).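

The ring carbon two ring bonds from the ring sulfur now carries a vinyl group, with its double bond outside the aromatic ring, and in this assay replacing bromo with vinyl gives no change at the digits printed from compound 3 to compound 4 (within the scatter) on the way to this result. Compared with the saturated chains at the same place, vinyl gives a 2.0-fold lower number from compound 2 to compound 4 (0.30 log units; within the scatter) and a 2.0-fold lower number from compound 1 to compound 4 (0.30 log units; within the scatter) in the same read-out, so bromo, vinyl, propyl and butyl cannot be told apart here, whether the group is a halogen, an unsaturated chain or a saturated one. No separate measurement is available to explain why these four compounds read so closely.

On these data alone, whether an amine or a carboxylic acid on this ring carbon, or a chain longer than butyl, would move the number beyond the scatter remains open. The four compounds also share the same core and the same attachment to the ring, so they cannot show how changes elsewhere in the structure would affect this read-out.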